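A few compounds are considered here, and "the series" means these few. Any claim that something is new, unique, unknown or untested is made for them only; others in the source may bear on it.

Measured compounds:
compound 1 `CCN(Cc1ccccc1)C(=O)C1CCN(S(=O)(=O)c2ccc(C(F)(F)F)nc2)CC1` — "not determined" (no result reported)
compound 2 `CCN(Cc1ccccc1)C(=O)C1CCN(S(=O)(=O)c2ccccn2)CC1` — "not determined" (no result reported)
compound 3 `CCN(Cc1ccccc1)C(=O)C1CCN(S(=O)(=O)c2ccc3cccnc3c2)CC1` — 66%

Among the measured compounds shown here, in a functional assay on CHO cells for positive allosteric modulation of muscarinic acetylcholine receptor M5 (Homo sapiens), read by calcium flux (on this read-out lower numbers stand for smaller maximal responses and higher numbers for larger maximal responses), compound 3 gives 66%, and that is the only number in hand: compound 1 and compound 2 carry no result in this assay, so compound 3 cannot be set against any neighbour, and no step between measured compounds is known. Compound 4 `CCN(Cc1ccccc1)C(=O)C1CCN(S(=O)(=O)c2ccc3nsnc3c2)CC1` is the next member to be tested. It differs from compound 3 in one place: a group of 9 heavy atoms (6 carbon, 2 nitrogen, 1 sulfur; one five-membered aromatic ring with 3 hetero atoms, one six-membered aromatic ring of carbon only) in place of a group of 10 heavy atoms (9 carbon, 1 nitrogen; one six-membered aromatic ring of carbon only, one six-membered aromatic ring with 1 hetero atom), on a sulfonyl sulfur. The shared core, the amide and the sulfonamide ring are untouched; only the bicyclic aromatic group on the sulfonyl sulfur is exchanged for another bicyclic aromatic group. For the measured compounds named here, with nothing but the single value of compound 3 to go on, the expected step is small, none beyond the scatter in either direction. Compound 4 is estimated to reach 60%, in a range from 35% to 85%. That estimate means a step of a number 6 percentage points lower from compound 3 to compound 4 (within the scatter), inside the usual scatter.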

Compound 4, largest response reached (reported as percent of maximum), in percent of the reference or control that the assay uses: 81%
Compound 4: the middle estimate sits 21 percentage points below what was measured; low and high end bracket the measured number.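

In this assay, among the compounds shown here, the response depends on which bicyclic aromatic group sits on the sulfonyl sulfur: replacing quinolin-7-yl with the group that has a five-membered aromatic ring with 3 hetero atoms gives a number 15 percentage points higher from compound 3 to compound 4 (beyond the scatter), the first step that can be read. Compound 4 thus shows that quinolin-7-yl can be exchanged at this place without losing the response. Nothing available explains this step. As far as these compounds go, it remains open whether an amine or a methoxy group on the bicyclic aromatic group would raise or lower the response further.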